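A few compounds are considered here, and "the series" means these few. Any claim that something is new, unique, unknown or untested is made for them only; others in the source may bear on it.

Measured in an ADME assay on HT-29 cells (Homo sapiens) for inhibition, read by MTT assay, with a stated time of 72 h; a lower number here means a stronger inhibitor, a higher number a weaker inhibitor:

Compound 1 `CN(C)C/C=C/C(=O)Nc1cccc(Nc2nc(N/N=C/c3ccc(F)cc3)ncc2Cl)c1` gives 3300 nM
Compound 2 `CN(C)C/C=C/C(=O)Nc1cccc(Nc2nc(N/N=C/c3ccc(F)cc3F)ncc2Cl)c1` gives 2920 nM
Compound 3 `C/C(=N\Nc1ncc(Cl)c(Nc2cccc(NC(=O)/C=C/CN(C)C)c2)n1)c1ccc(C)cc1` gives 11800 nM

All three share one core and differ only in the group attached to the hydrazone nitrogen. In this assay compound 3 stands highest of the three numbers: the step of a 3.6-fold higher number from compound 1 to compound 3 (0.55 log units; beyond the scatter) and the step of a 4.0-fold higher number from compound 2 to compound 3 (0.61 log units; beyond the scatter) both lie beyond the scatter, so compound 3 is the weakest inhibitor shown. By contrast the step of a 1.1-fold lower number from compound 1 to compound 2 (0.05 log units; within the scatter), a single small substituent swap on that aromatic ring, stays within the scatter.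

Compound 4 `COc1cccc(/C(C)=N/Nc2ncc(Cl)c(Nc3cccc(NC(=O)/C=C/CN(C)C)c3)n2)c1` follows from compound 3 by 3-methoxyphenyl in place of 4-methylphenyl on a carbon with a double bond to nitrogen. Among the compounds with values here, the only measured step that resembles this kind of change, one small substituent exchanged for another on the same ring, is a 1.1-fold lower number from compound 1 to compound 2 (0.05 log units; within the scatter), which was within the scatter; the two larger steps changed the whole group and so say little here. A change of no more than the scatter is therefore expected in this assay.

Compound 4 is estimated to give about 9500 nM in this assay, with a range from 3500 nM to 26000 nM. The expected step is a 1.2-fold lower number from compound 3 to compound 4 (0.09 log units; within the scatter).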

Compound 4, half-maximal inhibitory concentration: 3870 nM
Compound 4: the middle estimate sits 2.5-fold (0.39 log units) above what was measured; the measured number falls inside the stated range.
By their numbers in this assay, from the lowest: compounds 2, 1 and 4 (each within the scatter of the next); then compound 3.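

In this assay, within the data shown here, the swap on the carbon with a double bond to nitrogen is not a silent one: a 3.0-fold lower number from compound 3 to compound 4 (0.48 log units; beyond the scatter) shows that a substituent exchange on this ring can move the number beyond the scatter, which the fluoro step among the earlier compounds did not show. The other two comparisons, a 1.2-fold higher number from compound 1 to compound 4 (0.07 log units; within the scatter) and a 1.3-fold higher number from compound 2 to compound 4 (0.12 log units; within the scatter), both stay within the scatter, so a saturated chain carbon at this place does not by itself give a number as high as that of compound 3. No measurement shown here accounts for this step.

The methyl group of 4-methylphenyl and the methoxy group of 3-methoxyphenyl differ in both identity and ring position, so the compounds shown cannot separate these two changes. On these data alone, how a hydroxyl or an amine on this ring would compare also stays open.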